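Trading isopentyloxy for ethoxy on compound 1

The source may report more compounds than this note shows. Statements on the series, on what has been measured and on what is new or still open speak of the compounds shown alone.

In a functional assay on KB cells (Homo sapiens) for antiproliferative activity, read by sulforhodamine B assay, with a stated time of 3 days (on this read-out higher numbers stand for an effect only at larger amounts of compound and lower numbers for an effect already at smaller amounts), compound 1 (`CCCC1=C(OCCC(C)C)C(CCC)(CCC)C(=O)/C(=C(O)\C=C\c2ccccc2)C1=O`) gives 10.6 uM and sits within the usual scatter of the two other measured compounds. Compound 2 (`COC1=C(CC(C)C)C(=O)/C(=C(O)/C=C/c2ccccc2)C(=O)C1(CC(C)C)CC(C)C`) gives 7.9 uM and compound 3 (`CCCC1(CC=C(C)C)C(=O)C(C(=O)/C=C/c2ccccc2)=C(O)C(CCC)(CCC)C1=O`) gives 8.2 uM on the same read-out, so these three numbers cannot be put in a reliable order. No two of these compounds differ in one place only, so the data hold no direct measurement of any single structural change.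

Compound 4 (`CCCC1=C(OCC)C(CCC)(CCC)C(=O)/C(=C(O)\C=C\c2ccccc2)C1=O`) differs from compound 1 in one place (hydrogen in place of isopropyl on a saturated chain carbon, two bonds along the chain from an oxygen on an unsaturated carbon). Hydrogen stands in place of isopropyl on a saturated chain carbon, two bonds along the chain from an oxygen on an unsaturated carbon. The same difference reads isopentyloxy to ethoxy.

With compound 2 at 7.9 uM and compound 3 at 8.2 uM the measured compounds stay close together despite their differing groups, so no step beyond the scatter is expected here, in either direction. The estimated step is a 1.0-fold higher number from compound 1 to compound 4 (0.02 log units; within the scatter) and lies within the scatter. Compound 4 is expected at 11 uM with an estimated range of 5 uM to 25 uM as its likely span.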

Compound 4, concentration for half-maximal effect: 6.4 uM
Estimate against measurement, compound 4: 1.7-fold (0.24 log units) above; the measured number falls inside the stated range.
By their numbers in this assay, from the lowest: compounds 4, 2, 3 and 1 (each within the scatter of the next).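

Within the data shown here, compound 1 and compound 4 form the first pair in this set that differ in one place, so the effect of a single change can finally be read directly. In this assay, the exchange of isopentyloxy for ethoxy gives a 1.7-fold lower number from compound 1 to compound 4 (0.22 log units; within the scatter), a step within the usual scatter, so the two compounds cannot be put in a reliable order. At this position, on a saturated chain carbon, two bonds along the chain from an oxygen on an unsaturated carbon, removing the isopropyl and its three carbons therefore leaves no reliable mark on this read-out, and no independent measurement is available to explain that outcome.

On these data alone, whether the result would hold for a longer chain such as octyloxy, or for an ether chain ending in an amine or a carboxylic acid, remains open. This single pair also cannot show whether the same exchange would behave alike on a different core, such as that of compound 2, or in other cells.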